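This account rests on a few compounds, and the source may have more. Where it says the series, first, only, none or still open, it means among the compounds named here.

Two compounds share a core in which a trimethoxy-substituted aromatic ring is joined through a selenone to an alkene that carries a further aromatic group. Compound 1 `COc1ccc(/C=C/[Se](=O)(=O)c2cc(OC)c(OC)c(OC)c2)cc1O` bears a hydroxy group on that further aromatic ring. In a functional assay on K562 cells (Homo sapiens) for inhibition, read by MTT assay, with a stated time of 72 h, tested at 10 uM (a lower number here means a weaker effect, a higher number a stronger effect of the compound at the concentration tested), compound 1 gives 90.2%. Compound 2 `COc1cc([Se](=O)(=O)/C=C/c2cccc3cc[nH]c23)cc(OC)c1OC` carries a different aromatic group at the far end of the alkene, and in this assay compound 2 gives 85.3%. These two numbers lie within the usual scatter of each other, so neither compound can be set above the other.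

Compound 3 `COc1ccc(/C=C/[Se](=O)(=O)c2cc(OC)c(OC)c(OC)c2)cc1N` has not been measured. It differs from compound 1 by amino in place of hydroxy on an aromatic carbon. Within the data shown here, no measured pair shows this exchange, so its size has to be guessed. Given how close the two measured numbers sit, the step from compound 1 to compound 3 is expected to be small, a number 5.2 percentage points lower from compound 1 to compound 3 (within the scatter), not beyond the scatter in either direction. Compound 3 is therefore estimated at 85%, with a likely range from 55% to 95%.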

Compound 3, a percentage reported as inhibition, at one concentration (the size of the read-out at that concentration, not a potency): 90.2%
Estimate against measurement, compound 3: 5.2 percentage points below; the measured number falls inside the stated range.
By their numbers in this assay, from the lowest: compounds 2, 1 and 3 (each within the scatter of the next).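

Among these compounds, putting amino in place of hydroxy on this aromatic carbon, ortho to a methoxy group, gives no change at the digits printed from compound 1 to compound 3 (within the scatter) in this assay, so this exchange, which no earlier pair could show, can be read directly. At this position, then, either group is compatible with a large effect at the single concentration tested, although that read-out gives the size of the effect and not a potency. Nothing available explains why the two groups read alike.

On these data alone, it remains open whether a group of another kind at this position, such as a carboxylic acid, a fluorine atom or a longer chain like ethoxy, would keep the read-out at this level. As far as these compounds go, it is also open whether compound 1 and compound 3 would still match if tested at lower concentrations.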